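Shortening the propyl chain on the imidazopyrimidine core

The source may hold more compounds than are shown below. What is called first, only, known or untested is meant among the compounds shown, and "the series" means these compounds.

This account follows compound 2 `CCCc1cc(OC)nc2nc(C(=O)c3ccccc3)cn12` to compound 3 `COc1cc(C)n2cc(C(=O)c3ccccc3)nc2n1`. Within the data shown here, in a functional assay on the whole organism with Rattus norvegicus as the target (a higher number here means that more compound is needed for the effect, a lower number that less compound is needed), compound 2 gives 1 mg/kg, the lower of the two numbers known so far, while compound 1 `CCc1c(OC)nc2nc(C(=O)c3ccccc3)cn2c1C` gives 2 mg/kg; the two values lie within the scatter of each other, so no order can be read from them. Compound 3 carries the change (hydrogen in place of ethyl on a saturated chain carbon bound to an aromatic carbon). Among the measured compounds shown here, no step between measured compounds bears on this change, so the size is uncertain; a small rise in dose, or none beyond the scatter, is expected a 2.0-fold higher number from compound 2 to compound 3 (0.30 log units; within the scatter). Compound 3 is estimated at 2 mg/kg, ranging from 0.7 mg/kg to 6 mg/kg.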

Compound 3, minimum effective dose: 5 mg/kg
The estimate for compound 3 lay 2.5-fold (0.40 log units) below the measured number; the range from low to high includes it.
By their numbers in this assay, from the lowest: compounds 2 and 1 (each within the scatter of the next); then compound 3.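

In this assay the change from propyl to methyl on a saturated chain carbon bound to an aromatic carbon goes beyond the scatter (a 5.0-fold higher number from compound 2 to compound 3 (0.70 log units; beyond the scatter)), so the length of this chain matters, which the earlier pair could not show. The loss of ethyl on an aromatic carbon points the same way (a 2.5-fold higher number from compound 1 to compound 3 (0.40 log units; beyond the scatter)), so both steps raise the dose needed.

Going by these compounds, whether a longer chain such as butyl, or an amine on the chain, would lower the dose stays open. Nothing available here says why taking away these carbons raises the dose.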